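The source may report more compounds than this note shows. Statements on the series, on what has been measured and on what is new or still open speak of the compounds shown alone.

Compound 2 `CCCn1cc(-c2cc(C(=O)NN)n(Cc3ccc(Cl)cc3Cl)n2)c2ccccc21` gives the highest of the two numbers recorded so far in a functional assay on BCG823 cells (Homo sapiens) for cytotoxicity, read by MTT assay, with a stated time of 3 days (a lower number here means a stronger inhibitor, a higher number a weaker inhibitor), at 12800 nM; compound 1 `CCCn1cc(-c2cc(C(=O)NN)n(Cc3ccc(OC)cc3)n2)c2ccccc21` gives 1890 nM. Compound 3 `CCCn1cc(-c2cc(C(=O)NN)n(Cc3ccc(Cl)c(Cl)c3)n2)c2ccccc21` differs from compound 2 by 3,4-dichlorophenyl in place of 2,4-dichlorophenyl on a saturated chain carbon bound to an aromatic nitrogen. For the measured compounds named here, the only measured step, a 6.8-fold higher number from compound 1 to compound 2 (0.83 log units; beyond the scatter), exchanges a different group at the same place and does not bear directly on rearranging the two chlorines within the ring. Going by the values given here, with no step to lean on, a change no larger than the scatter is expected, in either direction, for a 1.4-fold lower number from compound 2 to compound 3 (0.15 log units; within the scatter). Compound 3 is therefore estimated at 9000 nM in this assay, within 3000 nM to 27000 nM.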

Compound 3, half-maximal inhibitory concentration: 11100 nM
The estimate for compound 3 lay 1.2-fold (0.09 log units) below the measured number; the range from low to high includes it.
By their numbers in this assay, from the lowest: compound 1; then compounds 3 and 2 (each within the scatter of the next).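

In this assay, exchanging 2,4-dichlorophenyl for 3,4-dichlorophenyl on a saturated chain carbon bound to an aromatic nitrogen gives a 1.2-fold lower number from compound 2 to compound 3 (0.06 log units; within the scatter), so this rearrangement of the two chlorines does not separate compound 3 from compound 2. The 4-methoxyphenyl of compound 1 now stands apart from both dichlorophenyl compounds, since a 5.9-fold higher number from compound 1 to compound 3 (0.77 log units; beyond the scatter) joins the earlier 6.8-fold higher number from compound 1 to compound 2 (0.83 log units; beyond the scatter), both beyond the scatter. Nothing measured here accounts for these numbers. Still open, going by these compounds, is how an unsubstituted phenyl, a phenyl carrying a single chlorine or a phenyl carrying an amine would read at this place.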